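Permeability notes: ring for isobutyl on the shared core

A few compounds are considered here, and "the series" means these few. Any claim that something is new, unique, unknown or untested is made for them only; others in the source may bear on it.

Measured so far in an ADME assay for permeability, using PAMPA, with a stated time of 30 min, at pH 7.4; on this read-out lower numbers stand for lower permeability and higher numbers for higher permeability:
compound 1 `COc1ccc(-c2ccc3c(NCCCNCc4cccc(OC)c4O)ccnc3c2)cc1`: 237 10^-6 cm/s
compound 2 `COc1cccc(CNCCCNc2ccnc3cc(Oc4ccc(F)cc4)ccc23)c1O`: 317 10^-6 cm/s
compound 3 `COc1cccc(CNCCCNc2ccnc3cc(CC(C)C)ccc23)c1O`: 23 10^-6 cm/s

Compound 3 gives the lowest of the three numbers, and the two steps leading to it, a 10-fold lower number from compound 1 to compound 3 (1.01 log units; beyond the scatter) and a 14-fold lower number from compound 2 to compound 3 (1.14 log units; beyond the scatter), are both large and run downward; between compound 1 and compound 2 the step of a 1.3-fold higher number from compound 1 to compound 2 (0.13 log units; within the scatter) is small. Compound 4 `COc1cccc(CNCCCNc2ccnc3cc(Cc4ccc(F)cc4Cl)ccc23)c1O` differs from compound 3 by 2-chloro-4-fluorophenyl in place of isopropyl on a saturated chain carbon bound to an aromatic carbon, so an aromatic ring re-enters at the same aromatic carbon, one bond further out than in compound 1 or compound 2. Both large steps bear on this change, and a rise of similar size is expected, a 7.8-fold higher number from compound 3 to compound 4 (0.89 log units; beyond the scatter). Compound 4 is therefore estimated at 180 10^-6 cm/s, with a range of 60 10^-6 cm/s to 400 10^-6 cm/s.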

Compound 4, apparent permeability: 23 10^-6 cm/s
The estimate for compound 4 lay 7.8-fold (0.89 log units) above the measured number, outside the stated range (below it).
By their numbers in this assay, from the lowest: compounds 3 and 4 (each within the scatter of the next); then compounds 1 and 2 (each within the scatter of the next).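

In this assay 2-chloro-4-fluorobenzyl in place of isobutyl gives no change at the digits printed from compound 3 to compound 4 (within the scatter) and so, on a saturated chain carbon bound to an aromatic carbon, an aromatic ring does not bring back the higher numbers. An aromatic ring in the substituent is therefore not enough by itself, as a 10-fold lower number from compound 1 to compound 4 (1.01 log units; beyond the scatter) and a 14-fold lower number from compound 2 to compound 4 (1.14 log units; beyond the scatter) are both large. The data shown give no measured cause for this.

On these data alone, whether the saturated chain carbon or the chlorine sets compound 4 apart stays open. A 4-fluorobenzyl or an unsubstituted benzyl on this aromatic carbon would separate the two.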